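Working notes: from compound 2 to compound 3

The source may hold more compounds than are shown below. What is called first, only, known or untested is meant among the compounds shown, and "the series" means these compounds.

Measured in a functional assay on RT-112 cells (Homo sapiens) for antiproliferative activity, read by MTT assay, with a stated time of 72 h; on this read-out lower numbers stand for stronger inhibition of growth and higher numbers for weaker inhibition of growth:
- Compound 1 `COc1cc(Nc2ncnc3c(NC(=O)Nc4cc(C)cc(C)c4)cccc23)cc(OC)c1`: 10100 nM
- Compound 2 `COc1cc(Nc2ncnc3c(NC(=O)Nc4ccc(F)cc4F)cccc23)cc(OC)c1`: 2460 nM

Compound 2 holds the lower of the two numbers in this assay. For the measured compounds named here, the only measured step is a 4.1-fold lower number from compound 1 to compound 2 (0.61 log units; beyond the scatter), a modest move beyond the scatter. The change to compound 3 `COc1cc(Nc2ncnc3c(NC(=O)c4ccc(CN(C)C)cc4)cccc23)cc(OC)c1` is 4-((dimethylamino)methyl)phenyl in place of (2,4-difluorophenyl)amino on a carbonyl carbon. The measured step exchanged one aryl group on an amide-type nitrogen and kept that nitrogen, whereas this change removes it, so the step bears only loosely. Going by the values given here, no measured compound carries the entering group, and the data fix no direction. A modest shift is expected, with a slight lean towards a higher number, and the range stays wide on both sides. The expected change is a 1.4-fold higher number from compound 2 to compound 3 (0.15 log units; within the scatter). Compound 3 is estimated at 3500 nM, with an expected range of 800 nM to 15000 nM.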

Compound 3, concentration for 50% growth inhibition: 4370 nM
For compound 3 the middle estimate is 1.2-fold (0.10 log units) below the measured one, within the range that was stated.
By their numbers in this assay, from the lowest: compounds 2 and 3 (each within the scatter of the next); then compound 1.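

In this assay, 4-((dimethylamino)methyl)phenyl in place of (2,4-difluorophenyl)amino on the carbonyl carbon gives a 1.8-fold higher number from compound 2 to compound 3 (0.25 log units; within the scatter), so this position accepts an exchange that removes the leaving group's nitrogen and hydrogen-bond donor with no change beyond the scatter. The same entering group in place of (3,5-dimethylphenyl)amino gives a 2.3-fold lower number from compound 1 to compound 3 (0.36 log units; beyond the scatter), a modest step that shows the read-out at this position does not depend on keeping that nitrogen in these three compounds. No evidence on hand accounts for either step.

The compounds shown do not separate the loss of the nitrogen from the entry of the dimethylamino group. A plain phenyl, or a phenyl carrying morpholinomethyl, on that carbonyl carbon would bear on that question.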